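The source may hold more compounds than are shown below. What is called first, only, known or untested is meant among the compounds shown, and "the series" means these compounds.

Working notes on the series.

Three amides sharing one core have numbers in a functional assay on A549 cells (Homo sapiens) for cytotoxicity, read by MTT assay, with a stated time of 72 h; on this read-out higher numbers stand for weaker inhibition and lower numbers for stronger inhibition. Compound 3 `O=C(Nc1ccc(Oc2ccncc2-c2cccnc2)c(F)c1)c1nn(-c2ccccc2)c(=O)c2ccccc12` carries an unsubstituted phenyl on the aromatic nitrogen; in this assay compound 3 gives 7900 nM, the highest of the three numbers. Compound 1 `COc1ccc(-n2nc(C(=O)Nc3ccc(Oc4ccncc4-c4cccnc4)c(F)c3)c3ccccc3c2=O)cc1`, with 4-methoxyphenyl in that position, gives 6800 nM in this assay, and a 1.2-fold higher number from compound 1 to compound 3 (0.07 log units; within the scatter). Compound 2 `O=C(Nc1ccc(Oc2ccncc2-c2cccnc2)c(F)c1)c1nn(-c2cccc(F)c2)c(=O)c2ccccc12`, with 3-fluorophenyl, gives 1750 nM in this assay; a 4.5-fold higher number from compound 2 to compound 3 (0.65 log units; beyond the scatter), and a 3.9-fold lower number from compound 1 to compound 2 (0.59 log units; beyond the scatter).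

Compound 4 `O=C(Nc1ccc(Oc2ccncc2-c2cccnc2)c(F)c1)c1nn(-c2ccc(F)cc2)c(=O)c2ccccc12` is the next step from compound 3: fluoro in place of hydrogen on an aromatic carbon, on an aromatic carbon of a six-membered aromatic ring of carbon only, para to a large group; read one bond further out, phenyl becomes 4-fluorophenyl. For the measured compounds named here, the step that bears most directly on it is the one from compound 2 to compound 3, where a fluoro on the same ring, at a different position, went with a modestly lower number. Against that, the step from compound 1 to compound 3 shows that a methoxy at the same position as the new fluoro left the number within the scatter. A lower number is therefore expected for compound 4, but smaller than the gain seen with compound 2, and the expected step is a 2.0-fold lower number from compound 3 to compound 4 (0.30 log units; within the scatter). In this assay compound 4 is estimated at 4000 nM, with a range from 1500 nM to 10000 nM.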

Compound 4, half-maximal inhibitory concentration: 820 nM
Estimate against measurement, compound 4: 4.9-fold (0.69 log units) above; the whole stated range lies above it.
By their numbers in this assay, from the lowest: compound 4; then compound 2; then compounds 1 and 3 (each within the scatter of the next).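

The place para to a large group on the phenyl proves responsive in this assay: with fluoro there, the change is a 9.6-fold lower number from compound 3 to compound 4 (0.98 log units; beyond the scatter), whereas the methoxy of compound 1 had left the number within the scatter of compound 3. The outcome at this place therefore depends on which group sits there, and exchanging methoxy for fluoro gives an 8.3-fold lower number from compound 1 to compound 4 (0.92 log units; beyond the scatter); the position of the fluoro also counts, with a 2.1-fold lower number from compound 2 to compound 4 (0.33 log units; beyond the scatter) when 4-fluorophenyl replaces 3-fluorophenyl. Nothing available accounts for these differences or shows what lies behind the read-out.

The compounds shown leave open whether this response is particular to fluoro or extends to other groups at the same place, such as chloro, trifluoromethyl, nitrile or an amine, and whether a ring such as 3,4-difluorophenyl would go further than either single fluoro. They also leave open whether the order of compound 4, compound 2 and the remaining pair holds when the amide side of the shared core is changed.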